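Aryl urea swap on the triazole-pyridine ether series

This account rests on a few compounds, and the source may have more. Where it says the series, first, only, none or still open, it means among the compounds named here.

Compound 1 `CCN(CC)CCn1cnnc1-c1cc(Oc2ccc(NC(=O)Nc3ccc(F)c(Cl)c3)cc2F)ccn1` gives 500 nM in a functional assay on HT-29 cells (Homo sapiens) for antiproliferative activity, read by MTT assay, with a stated time of 72 h; a higher number here means a weaker inhibitor, a lower number a stronger inhibitor. Compound 2 `CCN(CC)CCn1cnnc1-c1cc(Oc2ccc(NC(=O)Nc3ccc(Cl)cc3Cl)cc2F)ccn1` gives 3590 nM in this assay; the change from compound 1 to compound 2 is 2,4-dichlorophenyl in place of 3-chloro-4-fluorophenyl on an amide-type nitrogen, and the step is a 7.2-fold higher number from compound 1 to compound 2 (0.86 log units; beyond the scatter). Compound 3 `CN(C)CCCn1cnnc1-c1cc(Oc2ccc(NC(=O)Nc3ccc(F)c(Cl)c3)cc2F)ccn1` gives 890 nM in this assay; it differs from compound 1 by (dimethylamino)methyl in place of diethylamino on a saturated chain carbon, two bonds along the chain from an aromatic nitrogen, and the step is a 1.8-fold higher number from compound 1 to compound 3 (0.25 log units; within the scatter), so compound 1 and compound 3 cannot be told apart here.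

Compound 4 `CN(C)CCCn1cnnc1-c1cc(Oc2ccc(NC(=O)Nc3ccc(Cl)cc3Cl)cc2F)ccn1` is not yet measured in this assay. It differs from compound 3 by 2,4-dichlorophenyl in place of 3-chloro-4-fluorophenyl on an amide-type nitrogen, the same change that took compound 1 to compound 2, made at the same place. The two cores differ only by (dimethylamino)methyl in place of diethylamino on a saturated chain carbon, two bonds along the chain from an aromatic nitrogen, which left the number essentially unchanged. Going by the values given here, the step from compound 3 to compound 4 is therefore expected to be about a 6.7-fold higher number from compound 3 to compound 4 (0.83 log units; beyond the scatter), resting on the single earlier step of a 7.2-fold higher number from compound 1 to compound 2 (0.86 log units; beyond the scatter) and on compound 3 giving 890 nM. Compound 4 is estimated at 6000 nM in this assay, expected between 2500 nM and 15000 nM.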

Compound 4, half-maximal inhibitory concentration: 680 nM
The estimate for compound 4 lay 8.8-fold (0.95 log units) above the measured number, and the stated range ends above it.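

In this assay the swap to 2,4-dichlorophenyl gives a 1.3-fold lower number from compound 3 to compound 4 (0.12 log units; within the scatter), so the loss seen with the diethylamino chain does not carry over to the core bearing the dimethylamino chain: the same change on two cores in this assay, a 7.2-fold higher number (0.86 log units; beyond the scatter) from compound 1 to compound 2 and a 1.3-fold lower number (0.12 log units; within the scatter) from compound 3 to compound 4, 9.4-fold (0.97 log units) apart, beyond the scatter of two such steps. Read the other way, with 2,4-dichlorophenyl in place, the change from diethylamino to (dimethylamino)methyl gives a 5.3-fold lower number from compound 2 to compound 4 (0.72 log units; beyond the scatter), although the same change made no difference that could be read with 3-chloro-4-fluorophenyl, so neither change can be treated as independent of the other here: the same change on two cores in this assay, a 1.8-fold higher number (0.25 log units; within the scatter) from compound 1 to compound 3 and a 5.3-fold lower number (0.72 log units; beyond the scatter) from compound 2 to compound 4, 9.4-fold (0.97 log units) apart, beyond the scatter of two such steps. This rests on one square of four compounds and shows that the effect of the aryl swap depends on the core, but not why it does, nor whether compound 2 is a lone exception or part of a wider pattern.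

Going by these compounds, it remains open whether the same dependence appears with other aryl groups on the amide-type nitrogen, such as unsubstituted phenyl or 4-methoxyphenyl. On these data alone, it also remains open whether it appears with cyclic amines on the chain, such as pyrrolidine or morpholine.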